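The source may report more compounds than this note shows. Statements on the series, on what has been measured and on what is new or still open speak of the compounds shown alone.

Working notes on the series. Compound 1 `CCOC(=O)/C=C/[C@H]1C[C@@H](O)[C@@H](O)C1` and compound 2 `O=C(/C=C/[C@H]1C[C@@H](O)[C@@H](O)C1)Nc1ccc(C(F)(F)F)cc1` share one core. In an ADME assay on S2 cells (Drosophila melanogaster) for cytotoxicity, read by MTT assay (on this read-out lower numbers stand for an effect already at smaller amounts and higher numbers for an effect only at larger amounts of compound), compound 1 gives only a limit, > 350000 nM. In this assay compound 2 likewise gives only a limit, > 160000 nM. Compound 2 stands at the limit of > 160000 nM in this assay, at which 1 of the 2 values shown sits; no numbered reading exists anywhere in the set. Compound 3 `O=C(/C=C/[C@H]1C[C@@H](O)[C@@H](O)C1)Nc1ccc([N+](=O)[O-])cc1` differs from compound 2 by nitro in place of trifluoromethyl on an aromatic carbon. For the measured compounds named here, no measured pair carries this change, so the step from compound 2 to compound 3 is expected as a step that the limit leaves unreadable from compound 2 to compound 3, none beyond the scatter. For compound 3 the expected reading is 200000 nM, between 100000 nM and 400000 nM, most likely again a limit.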

Compound 3, half-maximal effective concentration: > 170000 nM
Compound 3: only a limit was reported; the forecaster's own chance of this, stated with the estimate: 75%; the middle value does not contradict the limit.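

For the compounds shown here, compound 2 and compound 3 both give only limits in this assay, so no step between them can be read. The compounds shown leave open whether nitro or trifluoromethyl changes the reading, as no numbered value exists for compound 1, compound 2 or compound 3.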